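A few compounds are considered here, and "the series" means these few. Any claim that something is new, unique, unknown or untested is made for them only; others in the source may bear on it.

Working notes on the series. Compound 3 `COCCO[C@H](CC=C(C)C)C1=CC(=O)c2c(O)ccc(O)c2C1=O` gives the highest number of the three in a functional assay on HeLa cells (Homo sapiens) for cytotoxicity, read by MTT assay (a higher number here means a weaker inhibitor, a lower number a stronger inhibitor), at 62400 nM. Compound 1 `CC(=O)OCCO[C@H](CC=C(C)C)C1=CC(=O)c2c(O)ccc(O)c2C1=O` gives 41500 nM, and the step of a 1.5-fold higher number from compound 1 to compound 3 (0.18 log units; within the scatter) allows no order between these two. Compound 2 `CC(C)=CC[C@@H](OC(=O)C1CCCO1)C1=CC(=O)c2c(O)ccc(O)c2C1=O` gives 17000 nM, and the step of a 3.7-fold higher number from compound 2 to compound 3 (0.56 log units; beyond the scatter) does separate it from compound 3.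

Compound 4 `CC(C)=CC[C@@H](OC(=O)C1CCCOC1)C1=CC(=O)c2c(O)ccc(O)c2C1=O` differs from compound 3 in one place: (oxan-3-yl)carbonyl in place of 2-methoxyethyl on an oxygen on a saturated carbon. Within the data shown here, the steps that bear on it are a 2.4-fold lower number from compound 1 to compound 2 (0.39 log units; beyond the scatter), where an acyclic ester was exchanged for a ring-bearing ester, and a 3.7-fold higher number from compound 2 to compound 3 (0.56 log units; beyond the scatter) in the opposite direction. Since (oxan-3-yl)carbonyl is a close relative of (oxolan-2-yl)carbonyl, a modest step down in this assay is expected, a 3.1-fold lower number from compound 3 to compound 4 (0.49 log units; beyond the scatter). Compound 4 is therefore estimated at 20000 nM, within 9000 nM to 45000 nM.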

Compound 4, half-maximal inhibitory concentration: 60500 nM
The estimate for compound 4 lay 3.0-fold (0.48 log units) below the measured number, outside the stated range (above it).
By their numbers in this assay, from the lowest: compound 2; then compounds 1, 4 and 3 (each within the scatter of the next).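

In this assay, a ring on the ester at this oxygen does not by itself bring the lower number: the step of a 3.6-fold higher number from compound 2 to compound 4 (0.55 log units; beyond the scatter) separates oxan-3-yl from oxolan-2-yl on the carbonyl carbon. By contrast, (oxan-3-yl)carbonyl is not told apart from 2-methoxyethyl by the step of a 1.0-fold lower number from compound 3 to compound 4 (0.01 log units; within the scatter) or from 2-acetoxyethyl by the step of a 1.5-fold higher number from compound 1 to compound 4 (0.16 log units; within the scatter) and so compound 2 alone stands apart. No evidence bears on the reason for this.

The compounds shown do not separate ring size from point of attachment on the carbonyl carbon. Going by these compounds, whether oxan-2-yl or an amine-bearing piperidinyl ring would follow compound 2 remains open.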